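A Nitrile Replaces Fluorine on the Sulfonyl Ring

The source may report more compounds than this note shows. Statements on the series, on what has been measured and on what is new or still open speak of the compounds shown alone.

Of the compounds shown here, two have been tested in a functional assay (Cavia porcellus) with sulfonylurea receptors; K-ATP channels (Homo sapiens) as the target; a lower number here means a stronger inhibitor, a higher number a weaker inhibitor. Compound 1 `CC(O)(C(=O)Nc1ccc(S(=O)(=O)c2ccccc2F)cc1)C(F)(F)F` carries a 2-fluorophenyl on the sulfonyl sulfur and gives 1300 nM. Compound 2 `CC(O)(C(=O)Nc1ccc(S(=O)(=O)c2ccc(F)cc2)cc1)C(F)(F)F` carries a 4-fluorophenyl instead and gives 8600 nM, the higher of the two numbers; the step of a 6.6-fold higher number from compound 1 to compound 2 (0.82 log units; beyond the scatter) shows that moving the fluorine to the 4-fluorophenyl arrangement weakened inhibition in this assay.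

Compound 3 `CC(O)(C(=O)Nc1ccc(S(=O)(=O)c2ccccc2C#N)cc1)C(F)(F)F` has not yet been measured. Its change is 2-cyanophenyl in place of 4-fluorophenyl on a sulfonyl sulfur. Among the measured compounds shown here, the only measured step that bears on it is the one between compound 1 and compound 2, which shows that a substituent placed as in 2-fluorophenyl gave a markedly lower number than one placed as in 4-fluorophenyl. For the measured compounds named here, compound 3 carries its substituent as in 2-cyanophenyl, so a return toward the number of compound 1 seems plausible, although the nitrile is new to the series and no step tells how it compares with fluorine. Compound 3 is therefore expected to give 1800 nM in this assay, within a range of 500 nM to 6500 nM, an expected step of a 4.8-fold lower number from compound 2 to compound 3 (0.68 log units; beyond the scatter).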

Compound 3, half-maximal inhibitory concentration: 1100 nM
Compound 3: middle estimate off by 1.6-fold (0.21 log units), on the high side; measured number inside the range.
By their numbers in this assay, from the lowest: compounds 3 and 1 (each within the scatter of the next); then compound 2.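

In this assay, replacing the 4-fluorophenyl with a 2-cyanophenyl on the sulfonyl sulfur gives a clear gain in inhibition (a 7.8-fold lower number from compound 2 to compound 3 (0.89 log units; beyond the scatter)). Placing cyano instead of fluoro on the same aromatic carbon leaves the number within the usual scatter (a 1.2-fold lower number from compound 1 to compound 3 (0.07 log units; within the scatter)), so this assay does not separate the 2-fluorophenyl and 2-cyanophenyl rings. Compounds with either of these two rings now give lower numbers than the compound with 4-fluorophenyl, and none of the three compounds goes against this, although the change to compound 3 alters both the group and its place on the ring, so that step alone cannot divide the gain between them.

The data shown offer no measurement that explains why these rings behave as they do. As far as these compounds go, it remains open whether 4-cyanophenyl would give a number close to that of the 4-fluorophenyl compound, and whether a plain phenyl, 2-chlorophenyl or 2-methoxyphenyl ring would match the two rings tested here.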